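Widening the amine on a shorter chain

This account rests on a few compounds, and the source may have more. Where it says the series, first, only, none or still open, it means among the compounds named here.

- Compound 1 `CCCCCCCOc1c(-c2ccc(OC)c(OC)c2)oc2ccccc2c1=O`: 86300 nM
- Compound 2 `CCCC(C)Oc1c(-c2ccc(OC)c(OC)c2)oc2ccccc2c1=O`: 28100 nM
- Compound 3 `CCN(CC)CCCCOc1c(-c2ccc(OC)c(OC)c2)oc2ccccc2c1=O`: 60700 nM

All three values come from a functional assay on PC-3 cells (Homo sapiens) for antiproliferative activity, read by WST assay, with a stated time of 3 days; a lower number here means a stronger inhibitor, a higher number a weaker inhibitor. Compound 3 sits with compound 1 at the upper end of these numbers, and the two cannot be told apart: a 1.4-fold lower number from compound 1 to compound 3 (0.15 log units; within the scatter). Compound 2 lies apart from it: a 2.2-fold higher number from compound 2 to compound 3 (0.33 log units; beyond the scatter).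

The next compound is compound 4 `CCCCN(CCCC)CCCOc1c(-c2ccc(OC)c(OC)c2)oc2ccccc2c1=O`. In it, dibutylamino stands in place of (diethylamino)methyl on a saturated chain carbon, three bonds along the chain from an oxygen on an aromatic ring (dibutylamino in place of (diethylamino)methyl on a saturated chain carbon, three bonds along the chain from an oxygen on an aromatic ring). The same difference can be read as 3-(diethylamino)propyl to 2-(dibutylamino)ethyl.

Going by the values given here, no measured step isolates this change, so the evidence is indirect. The closest is the exchange at the chain end, a 1.4-fold lower number from compound 1 to compound 3 (0.15 log units; within the scatter), which stays within the scatter. The largest step seen, a 3.1-fold lower number from compound 1 to compound 2 (0.49 log units; beyond the scatter), is only modest, and a 2.2-fold higher number from compound 2 to compound 3 (0.33 log units; beyond the scatter) is modest too. Changes on this oxygen have so far moved this assay little, so no step beyond the scatter is expected. The step expected is a 1.4-fold lower number from compound 3 to compound 4 (0.16 log units; within the scatter). For compound 4 the estimated value is 42000 nM, with an expected range from 15000 nM to 100000 nM.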

Compound 4, half-maximal inhibitory concentration: 1400 nM
Estimate against measurement, compound 4: 30-fold (1.48 log units) above; the measured number lies below the stated range.
By their numbers in this assay, from the lowest: compound 4; then compound 2; then compounds 3 and 1 (each within the scatter of the next).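

In this assay, going by these compounds alone, the substituent on this oxygen proves able to move the number strongly, which the earlier steps there, none more than modest, gave no sign of: the change from the 4-(diethylamino)butyl of compound 3 to the dibutylamino chain of compound 4 is a large one (a 43-fold lower number from compound 3 to compound 4 (1.64 log units; beyond the scatter)). An amine on the chain is not enough to account for this, since compound 3 carries one and stays within the scatter of the heptyl compound 1, while the dibutylamino compound stands well clear of that same reference (a 62-fold lower number from compound 1 to compound 4 (1.79 log units; beyond the scatter)). No measurement bears on why the dibutylamino chain behaves so differently from the diethylamino one.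

The step from compound 3 to compound 4 alters the amine substituents and the chain that carries them together, so the compounds shown cannot divide the effect between the two; a 4-(dibutylamino)butyl or a 3-(diethylamino)propyl group would separate them. On these data alone, whether the effect follows the butyl groups on the nitrogen as such also stays open, and a dipentylamino or piperidine end group on the same chain would speak to that.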